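From 2,4-dimethoxyphenyl to cyclohexyl on the shared core

The source may hold more compounds than are shown below. What is called first, only, known or untested is meant among the compounds shown, and "the series" means these compounds.

Measured in a functional assay on A549 cells (Homo sapiens) for inhibition, read by MTT assay, with a stated time of 48 h; a higher number here means a weaker inhibitor, a lower number a stronger inhibitor:
Compound 1 `c1ccc(C(c2c[nH]c3ccccc23)c2c[nH]c3ccccc23)cc1`: 40000 nM
Compound 2 `COc1ccc(C(c2c[nH]c3ccc(Br)cc23)c2c[nH]c3ccc(Br)cc23)cc1`: 10000 nM
Compound 3 `COc1ccc(C(c2c[nH]c3ccc(Br)cc23)c2c[nH]c3ccc(Br)cc23)c(OC)c1`: 100000 nM

Compound 3 is the weakest inhibitor of the three, at 100000 nM. Compound 1 sits nearest to it at 40000 nM, and compound 2 lies furthest away at 10000 nM. The next structure, compound 4 `Brc1ccc2[nH]cc(C(c3c[nH]c4ccc(Br)cc34)C3CCCCC3)c2c1`, has not yet been measured. It differs from compound 3 as follows: cyclohexyl in place of 2,4-dimethoxyphenyl on a saturated chain carbon bound to two aromatic carbons. In words, cyclohexyl stands in place of 2,4-dimethoxyphenyl on a saturated chain carbon bound to two aromatic carbons.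

Within the data shown here, only one measured step bears on this change: a 10-fold higher number from compound 2 to compound 3 (1.00 log units; beyond the scatter), which came with methoxy in place of hydrogen on an aromatic carbon. Compound 4 carries no methoxy, so that step points towards a lower number. Among the measured compounds shown here, the evidence is indirect, since no measured pair exchanges an aromatic ring for a non-aromatic one, and the expected gain is therefore set smaller than the measured step. In this assay, the estimated change is a 3.3-fold lower number from compound 3 to compound 4 (0.52 log units; beyond the scatter), which is a modest move towards stronger inhibition. For compound 4 the expected value is 30000 nM, with an estimated range of 8000 nM to 100000 nM.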

Compound 4, half-maximal inhibitory concentration: 5500 nM
Compound 4: the middle estimate sits 5.5-fold (0.74 log units) above what was measured, and the stated range ends above it.
By their numbers in this assay, from the lowest: compounds 4 and 2 (each within the scatter of the next); then compound 1; then compound 3.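

In this assay, the saturated chain carbon bound to two aromatic carbons proves able to carry a non-aromatic ring: cyclohexyl in place of 2,4-dimethoxyphenyl gives an 18-fold lower number from compound 3 to compound 4 (1.26 log units; beyond the scatter) and so reverses the weak result of compound 3. Cyclohexyl in place of 4-methoxyphenyl gives a 1.8-fold lower number from compound 2 to compound 4 (0.26 log units; within the scatter) in the same assay, so an aromatic ring at this carbon is not needed to reach the numbers of compound 2, and among the three bromine-bearing compounds only compound 3 stands apart. Nothing measured on these compounds explains why the numbers fall as they do.

The compounds shown leave open whether the same carbon would keep these numbers with a smaller saturated ring such as cyclopentyl, an open chain such as n-butyl, or a ring holding an amine such as piperidin-4-yl. They also do not separate the contribution of the bromine on the shared core from that of the group on this carbon, since compound 1 differs from compound 2 in more than one place.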